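This account rests on a few compounds, and the source may have more. Where it says the series, first, only, none or still open, it means among the compounds named here.

Measured so far:
Compound 1, `CC[C@@H](Nc1c(C#N)c(-c2ccc(-c3cccc(C)c3)cc2)nc2cnccc12)C(N)=O`: 3 in a physicochemical assay for lipophilicity, read by HPLC, at pH 7.5; a higher number here means a more lipophilic compound, a lower number a more polar compound.
Compound 2, `CC[C@@H](Nc1c(C#N)c(-c2ccc(-c3ccccc3COC)cc2)nc2cnccc12)C(N)=O`: 2.6.

Compound 2 holds the lower of the two numbers; its nearest neighbour is compound 1, and the distribution coefficient is a number 0.40 log units lower from compound 1 to compound 2 (beyond the scatter), a change beyond the scatter. Compound 3, `CC[C@@H](Nc1c(C#N)c(-c2ccc(-c3ccccc3C(F)(F)F)cc2)nc2cnccc12)C(N)=O`, differs from compound 2 in one place: trifluoromethyl in place of methoxymethyl on an aromatic carbon. For the measured compounds named here, one measured step bears on this change. From compound 1 to compound 2 a methoxymethyl group entered the same ring, and the number fell by a number 0.40 log units lower from compound 1 to compound 2 (beyond the scatter). In compound 3 that methoxymethyl leaves again, so at least that loss is expected to be recovered. Going by the values given here, no measured step shows trifluoromethyl entering, so the size of its own contribution is unknown here. The step is therefore expected to be upward, a number 0.70 log units higher from compound 2 to compound 3 (beyond the scatter). Compound 3 is estimated at 3.3, between 2.9 and 3.7.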

Compound 3, distribution coefficient: 3.1
Compound 3: the middle estimate sits 0.20 log units above what was measured, within the range that was stated.
By their numbers in this assay, from the lowest: compound 2; then compounds 1 and 3 (each within the scatter of the next).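

In this assay, on this aromatic carbon ortho to a large group, trifluoromethyl in place of methoxymethyl gives a number 0.50 log units higher from compound 2 to compound 3 (beyond the scatter). The comparison with 3-methylphenyl gives a number 0.10 log units higher from compound 1 to compound 3 (within the scatter), so a group at this ortho place does not by itself bring the number down: of the three compounds, only compound 2, which carries methoxymethyl, stands apart. Nothing measured here explains the difference between these two groups.

The compounds shown leave open how an amine, a carboxylic acid or a longer ether chain would read at this place. They also leave open whether trifluoromethyl would give a similar number on the ring carbon that holds the methyl group in compound 1.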